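The compounds below may be only part of what the source reports. "The series", "measured", "known", "first", "only" and "open" are said of these compounds alone.

Measured in a functional assay on HT-1080 cells (Homo sapiens), read by transwell migration, with a stated time of 24 h, tested at 0.1 uM; a lower number here means a stronger effect, a higher number a weaker effect of the compound at the concentration tested:
compound 1 `CC(=O)OCc1ccc2oc(=O)c(C(=O)Oc3cccc(Br)c3)cc2c1` gives 39.5%
compound 2 `CCCC(=O)OCc1ccc2oc(=O)c(C(=O)Oc3cccc(Br)c3)cc2c1` gives 88.6%
compound 3 `CCCCCC(=O)OCc1ccc2oc(=O)c(C(=O)Oc3cccc(Br)c3)cc2c1` gives 94.3%

Compound 3 holds the highest of the three numbers. Compound 2 stands close to it, within the scatter, while compound 1 lies far lower, as the step of a number 54.8 percentage points higher from compound 1 to compound 3 (beyond the scatter) shows. Compound 4 `CCCCCCC(=O)OCc1ccc2oc(=O)c(C(=O)Oc3cccc(Br)c3)cc2c1` differs from compound 3 by methyl in place of hydrogen on a saturated chain carbon, five bonds along the chain from a carbonyl carbon, so the ester chain grows once more at its far end. The step most like this one is a number 5.7 percentage points higher from compound 2 to compound 3 (within the scatter), which lengthened the same chain and stayed within the scatter. The large step of a number 49.1 percentage points higher from compound 1 to compound 2 (beyond the scatter) started from a much shorter chain and bears less on this change. For compound 4 no step beyond the scatter is therefore expected, a number 0.3 percentage points lower from compound 3 to compound 4 (within the scatter). Compound 4 is estimated at 94%, with a range from 82% to 105%.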

Compound 4, a percentage reported as activity, at one concentration (the size of the read-out at that concentration, not a potency): 89.4%
For compound 4 the middle estimate is 4.6 percentage points above the measured one, within the range that was stated.
By their numbers in this assay, from the lowest: compound 1; then compounds 2, 4 and 3 (each within the scatter of the next).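

In this assay the chain can grow further at its far end without a clear change, as a number 4.9 percentage points lower from compound 3 to compound 4 (within the scatter) and a number 0.8 percentage points higher from compound 2 to compound 4 (within the scatter) show. Against that, a number 49.9 percentage points higher from compound 1 to compound 4 (beyond the scatter) remains large, so among these four compounds the one clear divide lies between compound 1 and the other three. Still open, as far as these compounds go, is whether a longer chain, a branched chain or an amine at the end of the chain would keep the number this high or bring it back toward that of compound 1. Nothing available here gives a reason for this divide.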